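The source may report more compounds than this note shows. Statements on the series, on what has been measured and on what is new or still open speak of the compounds shown alone.

Working notes on the hydroxamic acid series in an ADME assay on cells (Hepatocyte, Homo sapiens) for pharmacokinetics, read by LC-MS, with a stated time of 90 min, tested at 1 uM; a higher number here means faster removal of the compound, a lower number slower removal.

Compound 1 `O=C(CCCCCNc1c(Nc2ccccc2)c(=O)c1=O)NO` is the parent of the set. In this assay compound 1 gives < 4.8 uL/min, which is a limit of the assay and not a number. Compound 2 `CN(C)c1ccc(Nc2c(NCCCCCC(=O)NO)c(=O)c2=O)cc1` differs from compound 1 in the core by dimethylamino in place of hydrogen on an aromatic carbon. In this assay compound 2 gives < 5 uL/min, again a limit rather than a number. Compound 3 `CC(CCCCC(=O)NO)Nc1c(Nc2ccccc2)c(=O)c1=O` differs from compound 1 by methyl in place of hydrogen on a saturated chain carbon bound to a nitrogen on an aromatic ring and a saturated chain carbon. In this assay compound 3 gives < 5 uL/min, also a limit of the assay. The step that the two limits leave unreadable from compound 1 to compound 2 and the step that the two limits leave unreadable from compound 1 to compound 3 therefore cannot be sized, since every value sits either at the limit of < 4.8 uL/min in this assay, at which 1 of the 3 values shown sits, or at the limit of < 5 uL/min in this assay, at which 2 of the 3 values shown sit.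

Compound 4 `C[C@H](CCCCC(=O)NO)Nc1c(Nc2ccc(N(C)C)cc2)c(=O)c1=O` is not yet measured. It differs from compound 2 by methyl in place of hydrogen on a saturated chain carbon bound to a nitrogen on an aromatic ring and a saturated chain carbon, the same change that was made from compound 1 to compound 3; the place of the change is described in the same words in both cases. The cores of compound 2 and compound 4 are the same, and how that core differs from the core of compound 1 is set out with compound 2.

Compound 3 stayed at a limit after this change, as its value < 5 uL/min shows. Compound 4 is expected to behave alike, with an estimated step that the limit leaves unreadable from compound 2 to compound 4. Compound 4 is estimated in this assay at 4 uL/min, between 2 uL/min and 9 uL/min, and most likely again as a limit.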

Compound 4, intrinsic clearance in a liver preparation (reported as CLH), per the amount of preparation that the assay uses: < 5 uL/min
Compound 4: only a limit was reported; the forecaster's own chance of this, stated with the estimate: 70%; the middle value lies beyond the limit too.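

In this assay compound 4 gives < 5 uL/min, a limit of the assay and not a number. With compound 2 also at a limit, no step can be read between compound 2 and compound 4. The compounds shown leave open how fast any of the four is removed in this assay, and whether dimethylamino or methyl in place of hydrogen changes that removal at all.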